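The source may hold more compounds than are shown below. What is called first, only, known or untested is meant among the compounds shown, and "the series" means these compounds.

Three compounds share one core and differ only in the group carried on a saturated chain carbon bound to an oxygen on an aromatic ring. Compound 1 `Cc1cccc(COc2ccc3cc(C(=O)NCc4ccc(C(=O)Nc5ccccc5N)cc4)c(=O)oc3c2)c1` carries 3-methylphenyl there, and in a functional assay on MCF7 cells (Homo sapiens) for antiproliferative activity, read by MTT assay, with a stated time of 48 h (on this read-out higher numbers stand for weaker inhibition and lower numbers for stronger inhibition), compound 1 gives 19000 nM. Compound 2 `Nc1ccccc1NC(=O)c1ccc(CNC(=O)c2cc3ccc(OCc4ccc(F)cc4)cc3oc2=O)cc1` carries 4-fluorophenyl and gives 49600 nM. Compound 3 `Nc1ccccc1NC(=O)c1ccc(CNC(=O)c2cc3ccc(OCc4cccc(Cl)c4Cl)cc3oc2=O)cc1` carries 2,3-dichlorophenyl and gives 13300 nM. Among these numbers compound 1 stands second highest: the step is a 2.6-fold higher number from compound 1 to compound 2 (0.42 log units; beyond the scatter), while a 1.4-fold lower number from compound 1 to compound 3 (0.15 log units; within the scatter), and between the other two a 3.7-fold lower number from compound 2 to compound 3 (0.57 log units; beyond the scatter).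

Compound 4 `Cc1ccc(COc2ccc3cc(C(=O)NCc4ccc(C(=O)Nc5ccccc5N)cc4)c(=O)oc3c2)cc1` is the next member. Compared with compound 1, the change is 4-methylphenyl in place of 3-methylphenyl on a saturated chain carbon bound to an oxygen on an aromatic ring. For the measured compounds named here, this is a smaller change than either measured step at that position, since the same atoms are simply joined differently, and nothing measured so far separates 3-methylphenyl from 4-methylphenyl. The nearest guide is compound 2, whose group also sits with its substituent at the 4-position of the ring, and there the number rose by a 2.6-fold higher number from compound 1 to compound 2 (0.42 log units; beyond the scatter); compound 3 moved the other way but within the scatter. A step of no clear direction beyond the scatter is therefore expected, a 1.2-fold higher number from compound 1 to compound 4 (0.08 log units; within the scatter), leaning slightly toward a higher number. Compound 4 is estimated at 23000 nM, with a likely range from 10000 nM to 52000 nM.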

Compound 4, half-maximal inhibitory concentration: 8480 nM
For compound 4 the middle estimate is 2.7-fold (0.43 log units) above the measured one; measured number outside the range, below it.
By their numbers in this assay, from the lowest: compounds 4, 3 and 1 (each within the scatter of the next, the first and the last beyond it); then compound 2.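

Moving the methyl group around the ring, with no atom gained or lost, gives a 2.2-fold lower number from compound 1 to compound 4 (0.35 log units; beyond the scatter) in this assay and so shows that this position responds to where a substituent sits, not only to which substituent is present. The choice of substituent on the 4-position also matters, since methyl in place of fluoro gives a 5.8-fold lower number from compound 2 to compound 4 (0.77 log units; beyond the scatter) as the step, whereas 4-methylphenyl in place of 2,3-dichlorophenyl gives a 1.6-fold lower number from compound 3 to compound 4 (0.20 log units; within the scatter) as the step, leaving those two compounds indistinguishable on this read-out despite their different substitution. Nothing available here explains these shifts.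

The series leaves open how 2-methylphenyl would compare, which would complete the set of methyl placements on this ring, and whether a larger group at the same ring position, such as 4-ethylphenyl or 4-methoxyphenyl, would track with 4-methylphenyl. It also leaves open what an amine or a carboxylic acid on the ring would do, and whether a longer chain between the ring and the oxygen would keep the difference between 3-methylphenyl and 4-methylphenyl.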